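This account rests on a few compounds, and the source may have more. Where it says the series, first, only, none or still open, it means among the compounds named here.

Compound 1 `c1ccc(COc2ccccc2Nc2ncnc3cc4c(cc23)OCCOCCOCCO4)cc1` and compound 2 `FC(F)(F)c1ccc(COc2ccccc2Nc2ncnc3cc4c(cc23)OCCOCCOCCO4)cc1` share one core and differ in a single group. In a functional assay on HepG2 cells (Homo sapiens) for antiproliferative activity, read by MTT assay, with a stated time of 72 h (a higher number here means a weaker inhibitor, a lower number a stronger inhibitor), compound 1 gives 37300 nM. Compound 2 in this assay gives > 100000 nM, which is a limit of the measurement rather than a number. The change between them, trifluoromethyl in place of hydrogen on an aromatic carbon, gave an at least 2.6-fold higher number from compound 1 to compound 2 (0.42 log units; beyond the scatter); the value of compound 2 sits at the limit of > 100000 nM in this assay, at which 1 of the 2 values shown sits. Compound 3 `O=[N+]([O-])c1ccc(COc2ccccc2Nc2ncnc3cc4c(cc23)OCCOCCOCCO4)cc1` carries nitro in place of trifluoromethyl on an aromatic carbon. Within the data shown here, the one measured step involves trifluoromethyl and not nitro, so it shows only that a group at this place can shift the number in this assay; it gives no direction for nitro. Compound 3 is expected to remain weak, with a step of an at least 1.4-fold lower number from compound 2 to compound 3 (0.15 log units; that floor lies within the scatter). The estimate for compound 3 in this assay is 70000 nM, in a range from 25000 nM to 200000 nM.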

Compound 3, half-maximal inhibitory concentration: 60800 nM
Compound 3: the middle estimate sits 1.2-fold (0.06 log units) above what was measured; the measured number falls inside the stated range.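

With nitro at this place, para to a large group, the change from hydrogen gives a 1.6-fold higher number from compound 1 to compound 3 (0.21 log units; within the scatter), so in this assay the clear shift seen with trifluoromethyl does not appear with nitro. The change from trifluoromethyl to nitro gives an at least 1.6-fold lower number from compound 2 to compound 3 (0.21 log units; that floor lies within the scatter), so these two groups cannot be firmly ranked against each other. The value of compound 2 is a limit of the assay and not a number, so this step has only a floor: the limit of > 100000 nM in this assay, at which 1 of the 3 values shown sits.

The compounds shown leave open whether an amine or a carboxylic acid at this place would move the number beyond the scatter in this assay. Going by these compounds, it also remains open whether any group here could give a number clearly lower than that of compound 1.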